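A few compounds are considered here, and "the series" means these few. Any claim that something is new, unique, unknown or untested is made for them only; others in the source may bear on it.

Compound 2, `COc1cc(Cl)cc(-c2nn(-c3cccc(NC(=O)Nc4ccc(Cl)c(C(F)(F)F)c4)c3)cc2-c2ccncc2)c1`, is one of three compounds tested in a functional assay on NCI-H23 cells (Homo sapiens) for inhibition, read by sulforhodamine B assay, with a stated time of 48 h, tested at 10 uM (a lower number here means a stronger effect, a higher number a weaker effect of the compound at the concentration tested), where it gives 0.3%. Of the three numbers this is the second highest. Going by the values given here, its nearest neighbour is compound 1, `COc1cc(Cl)cc(-c2nn(-c3cccc(NC(=O)Nc4cccc(C(F)(F)F)c4)c3)cc2-c2ccncc2)c1`, which gives -5.1%; the one measured step, a number 5.4 percentage points higher from compound 1 to compound 2 (within the scatter), lies within the scatter. Far from both stands compound 3, `COc1cc(Cl)cc(-c2nn(-c3cccc(NC(=O)c4cc(C(F)(F)F)cc(C(F)(F)F)c4)c3)cc2-c2ccncc2)c1`, which gives 72.1%, a much weaker effect than compound 2.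

The unmeasured compound 4, `COc1cc(Cl)cc(-c2nn(-c3cccc(NC(=O)c4ccc(Cl)c(Cl)c4)c3)cc2-c2ccncc2)c1`, differs from compound 2 in one place: 3,4-dichlorophenyl in place of (4-chloro-3-(trifluoromethyl)phenyl)amino on a carbonyl carbon. Among the compounds with values here, no measured step in this assay follows the same change. The only pointer is the gap between compound 2 and compound 3, whose values differ by far more than the scatter, with the compound carrying the carbonyl bound directly to an aromatic ring showing the much weaker effect. Within the data shown here, compound 4 also places an aromatic ring directly on the carbonyl carbon, so a shift toward a weaker effect, a number 54.7 percentage points higher from compound 2 to compound 4 (beyond the scatter), is expected, with wide uncertainty given that only one such compound is known. Compound 4 is therefore estimated at 55% in this assay, within a range from 15% to 85%.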

Compound 4, a percentage reported as activity, at one concentration (the size of the read-out at that concentration, not a potency): 75.3%
Compound 4: the middle estimate sits 20.3 percentage points below what was measured; the measured number falls inside the stated range.
By their numbers in this assay, from the lowest: compounds 1 and 2 (each within the scatter of the next); then compounds 3 and 4 (each within the scatter of the next).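

In this assay, the replacement on the carbonyl carbon now has a measured size in two pairs: a number 75 percentage points higher from compound 2 to compound 4 (beyond the scatter) when 3,4-dichlorophenyl replaces (4-chloro-3-(trifluoromethyl)phenyl)amino, and a number 80.4 percentage points higher from compound 1 to compound 4 (beyond the scatter) when it replaces (3-(trifluoromethyl)phenyl)amino. The high number does not depend on trifluoromethyl on the ring bound to the carbonyl, since compound 3 gives 72.1% with that group present and compound 4 gives 75.3% without it, two values within the scatter of each other. Nothing measured here explains why the replacement has so large a step in this assay.

The step changes the link to the carbonyl and the ring substituents together, so the compounds shown cannot separate the loss of the amino nitrogen from the exchange of trifluoromethyl for chloro. Going by these compounds, it also remains open whether a methylene or an ether oxygen in place of that amino nitrogen, with the 4-chloro-3-(trifluoromethyl)phenyl ring kept, would give a number near that of compound 2 or near that of compound 4.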